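This account rests on a few compounds, and the source may have more. Where it says the series, first, only, none or still open, it means among the compounds named here.

In a functional assay on A549 cells (Homo sapiens) for cytotoxicity, read by sulforhodamine B assay, with a stated time of 48 h (a lower number here means that less compound is tolerated, a higher number that more compound is tolerated), three compounds have so far been measured. Compound 1 `ClCc1cccc(Cn2cnc3c(Cl)ncnc32)c1` gives 79400 nM. Compound 3 `ClCc1cccc(Cn2cnc3c(Cl)nc(Cl)nc32)c1` gives 52500 nM. The change that turns compound 3 into compound 1 is hydrogen in place of chloro on an aromatic carbon. That step is a 1.5-fold higher number from compound 3 to compound 1 (0.18 log units; within the scatter). Compound 2 `ClCc1ccc(Cn2cnc3nc(Cl)nc(Cl)c32)cc1` gives 7940 nM, the lowest of the three numbers; compound 3 and compound 1 sit far above it, and the difference between the core of compound 2 and the core of compound 3 is not broken down here.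

Compound 4 `ClCc1ccc(Cn2cnc3ncnc(Cl)c32)cc1` has not yet been measured in this assay. Going by the values given here, it arises from compound 2 by hydrogen in place of chloro on an aromatic carbon, which is the same change as the one leading from compound 3 to compound 1, described at a place with the same surroundings word for word. Among the compounds with values here, because the one measured example of this change gave a 1.5-fold higher number from compound 3 to compound 1 (0.18 log units; within the scatter), a step of similar size is expected here, namely a 1.5-fold higher number from compound 2 to compound 4 (0.18 log units; within the scatter). On that basis compound 4 is expected to give about 12000 nM, most likely somewhere between 4000 nM and 40000 nM.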

Compound 4, concentration lethal to 50% of the cells: 9330 nM
The estimate for compound 4 lay 1.3-fold (0.11 log units) above the measured number; the range from low to high includes it.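

In this assay, hydrogen in place of chloro on an aromatic carbon between two ring nitrogen atoms gives a 1.2-fold higher number from compound 2 to compound 4 (0.07 log units; within the scatter). The change therefore carries from one core to the other without a difference that can be told from the scatter: the same change on two cores in this assay, a 1.5-fold higher number (0.18 log units; within the scatter) from compound 3 to compound 1 and a 1.2-fold higher number (0.07 log units; within the scatter) from compound 2 to compound 4, 1.3-fold (0.11 log units) apart, within the scatter of two such steps

This shows only that, on these two cores, losing this chloro group leaves the number in this cytotoxicity read-out essentially unchanged. It does not establish a rule for the series, since two pairs cannot show that the same would hold on any further core. The compounds shown leave open whether an amine or a methoxy group at that carbon would behave like hydrogen. They also leave open what replacing the remaining chloro group on the ring with an amine, or the chloromethyl group with a plain methyl or a hydroxymethyl group, would do to the number.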